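The compounds below may be only part of what the source reports. "The series", "measured", "known", "first", "only" and "open" are said of these compounds alone.

Compound 1 `CC(C)(C)N(NC(=O)c1ccccc1)C(=O)c1ccccc1Cl`: 75.9 nM
Compound 2 `CCc1ccccc1C(=O)N(NC(=O)c1ccccc1)C(C)(C)C`: 589 nM
Compound 3 `Cc1cc(C)cc(C(=O)N(NC(=O)c2ccccc2)C(C)(C)C)c1`: 69.2 nM

These three were measured in an assay on cells for agonist activity at ecdysone receptor (Bombyx mori), read by a luciferase reporter, with a stated time of 24 h; a lower number here means that less compound is needed, a higher number that more compound is needed for the effect. Compound 1 stands second highest of the three numbers; its nearest neighbour is compound 3, reached by a 1.1-fold lower number from compound 1 to compound 3 (0.04 log units; within the scatter), and its furthest is compound 2, reached by a 7.8-fold higher number from compound 1 to compound 2 (0.89 log units; beyond the scatter). Compound 4 `CC(C)(C)N(NC(=O)c1cccc(Cl)c1)C(=O)c1ccccc1Cl` differs from compound 1 by chloro in place of hydrogen on an aromatic carbon. Among the compounds with values here, this change falls on the ring that no measured step has touched: the steps of a 7.8-fold higher number from compound 1 to compound 2 (0.89 log units; beyond the scatter) and an 8.5-fold lower number from compound 2 to compound 3 (0.93 log units; beyond the scatter) both concern the other aromatic ring, so none of them bears directly on it. For compound 4 a step of a 1.3-fold lower number from compound 1 to compound 4 (0.10 log units; within the scatter) in this assay is therefore expected, not beyond the scatter. Compound 4 is estimated to give 60 nM, between 20 nM and 200 nM.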

Compound 4, half-maximal effective concentration: 155 nM
Compound 4: the middle estimate sits 2.6-fold (0.41 log units) below what was measured; low and high end bracket the measured number.
By their numbers in this assay, from the lowest: compounds 3 and 1 (each within the scatter of the next); then compound 4; then compound 2.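

In this assay, within the data shown here, the change from phenyl to 3-chlorophenyl brings a 2.0-fold higher number from compound 1 to compound 4 (0.31 log units; beyond the scatter) and so gives the first reading on the ring that the earlier steps left untouched. It shows that this ring does respond to a new group on this aromatic carbon, though the step is modest. The data shown offer no measured reason for this shift.

From the compounds shown here alone, whether the step belongs to chloro alone remains open. A methoxy group or an amine on the same carbon would test this.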